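A few compounds are considered here, and "the series" means these few. Any claim that something is new, unique, unknown or untested is made for them only; others in the source may bear on it.

Compound 2, `CCOC(=O)c1cnc(N2CCN(Cc3ccccc3C(=O)OC)CC2)nc1Oc1c(C)cc(-c2ccc(C#N)cc2)cc1C`, is one of two compounds examined in an ADME assay on MT4 cells (Homo sapiens) for cytotoxicity, read by MTT assay, with a stated time of 4 days; a lower number here means that less compound is tolerated, a higher number that more compound is tolerated. In this assay compound 2 gives > 125000 nM, which is a limit of the assay rather than a number. Compound 1, `CCOC(=O)c1cnc(N2CCN(Cc3ccccc3C(F)(F)F)CC2)nc1Oc1c(C)cc(-c2ccc(C#N)cc2)cc1C`, differs from it by a trifluoromethyl where compound 2 carries a methoxycarbonyl on an aromatic carbon. In this assay compound 1 also gives > 125000 nM, again a limit of the assay. The step that the two limits leave unreadable from compound 1 to compound 2 therefore cannot be read, because of the limit of > 125000 nM in this assay, at which 2 of the 2 values shown sit. Compound 3, `CCOC(=O)c1cnc(N2CCN(Cc3ccc(S(C)(=O)=O)cc3)CC2)nc1Oc1c(C)cc(-c2ccc(C#N)cc2)cc1C`, has not yet been measured. It differs from compound 2 by 4-(methylsulfonyl)phenyl in place of 2-(methoxycarbonyl)phenyl on a saturated chain carbon bound to an amine nitrogen in a ring. Going by the values given here, the only measured step concerns a different part of the molecule and yields no size; both values shown stop at the same limit, so there is no measured change of this kind to lean on. From this the step of a number no higher from compound 2 to compound 3 (the limit leaves the size open) is expected to be none beyond the scatter. Compound 3 is thus estimated at 125000 nM in this assay, within a range from 60000 nM to 250000 nM, and is most likely to stop at the same limit.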

Compound 3, half-maximal cytotoxic concentration: > 125000 nM
Compound 3 gave a limit, no number (the forecaster's own chance of this, stated with the estimate: 75%); the middle value sits exactly at the limit.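

Compound 3, like compound 1 and compound 2, stops at a limit of the assay in this assay, so the steps from compound 2 to compound 3 and from compound 1 to compound 3 cannot be read: (the limit of > 125000 nM in this assay, at which 3 of the 3 values shown sit). The compounds shown leave open where the half-maximal cytotoxic concentration of any of the three actually lies, and whether the exchanged groups alter it.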